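The source may hold more compounds than are shown below. What is called first, only, known or untested is meant among the compounds shown, and "the series" means these compounds.

Measured compounds:
compound 1 `CCc1cc(C(=O)N[C@@H](C)c2nc(-c3cccc(C)c3)no2)n(C)n1`, an assay on T-REx-293 cells for inhibition of potassium channel subfamily T member 1 (Homo sapiens), read by patch clamp; on this read-out lower numbers stand for stronger inhibition and higher numbers for weaker inhibition: 335 nM
compound 2 `Cc1cc(-c2noc([C@H](C)NC(=O)c3cc(C(F)(F)F)nn3C)n2)ccn1`, this assay: 165 nM

Compound 2 gives the lowest of the two numbers in this assay; compound 1 gives the higher number, and the gap between the two lies beyond the usual scatter.

Compound 3 `CNc1cc(-c2noc([C@H](C)NC(=O)c3cc(C(F)(F)F)nn3C)n2)ccn1` differs from compound 2 by methylamino in place of methyl on an aromatic carbon. Among the compounds with values here, no measured pair here carries the same change, so there is nothing to anchor its direction. The step is expected to be modest, close to the scatter, with no strong lean either way. Compound 3 is estimated at 200 nM, with a range from 70 nM to 600 nM. The expected step is a 1.2-fold higher number from compound 2 to compound 3 (0.08 log units; within the scatter).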

Compound 3, half-maximal inhibitory concentration: 195 nM
The estimate for compound 3 lay 1.0-fold (0.01 log units) above the measured number, and the stated range covers the measured number.
By their numbers in this assay, from the lowest: compounds 2, 3 and 1 (each within the scatter of the next, the first and the last beyond it).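

Methylamino in place of methyl, on the aromatic carbon next to the ring nitrogen, gives a 1.2-fold higher number from compound 2 to compound 3 (0.07 log units; within the scatter) in this assay. This position therefore takes a hydrogen-bond donor and acceptor with no shift beyond the scatter, which compounds 1 and 2 could not show. No supporting evidence bears on this result.

Open, on these data alone, is whether a primary amine, dimethylamino or methoxy at this position would stay as close to compound 2. Also open, as far as these compounds go, is whether the same change would read alike with ethyl in place of trifluoromethyl.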